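Nitrophenyl oxadiazole glycosides: acetate to tosylate at the chain

This account rests on a few compounds, and the source may have more. Where it says the series, first, only, none or still open, it means among the compounds named here.

Measured so far:
compound 1, `Nc1nnc(SC[C@H]2O[C@@H](OCc3noc(-c4ccc([N+](=O)[O-])cc4)n3)[C@@H]3OC4(CCCC4)O[C@@H]32)s1`: 19000 nM
compound 2, `CC(=O)OC[C@H]1O[C@@H](OCc2noc(-c3ccc([N+](=O)[O-])cc3)n2)[C@@H]2OC3(CCCC3)O[C@@H]21`: 52000 nM

In a functional assay on T47D cells (Homo sapiens) for antiproliferative activity, read by sulforhodamine B assay, with a stated time of 48 h (a lower number here means a stronger inhibitor of growth, a higher number a weaker inhibitor of growth), compound 1 gives 19000 nM, and compound 2 gives 52000 nM. Going by the values given here, compound 2 stands highest of the two numbers, with compound 1 its nearest neighbour; the single measured step is a 2.7-fold higher number from compound 1 to compound 2 (0.44 log units; beyond the scatter).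

Compound 3, `Cc1ccc(S(=O)(=O)OC[C@H]2O[C@@H](OCc3noc(-c4ccc([N+](=O)[O-])cc4)n3)[C@@H]3OC4(CCCC4)O[C@@H]32)cc1`, differs from compound 2 by (4-methylphenyl)sulfonyl in place of acetyl on an oxygen on a saturated carbon. Among the compounds with values here, no measured step covers this exchange. Within the data shown here, the only step known, a 2.7-fold higher number from compound 1 to compound 2 (0.44 log units; beyond the scatter), touches the same oxygen-bearing chain carbon but swaps a different group, and it was modest. There is thus no measured basis for a large move in this assay in either direction, and the working expectation is a number close to that of compound 2, probably within the scatter.

Compound 3 is therefore estimated at 40000 nM, with a range of 15000 nM to 110000 nM. This estimate corresponds to an expected step of a 1.3-fold lower number from compound 2 to compound 3 (0.11 log units; within the scatter).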

Compound 3, concentration for 50% growth inhibition: > 100000 nM
Compound 3: only a limit was reported; the forecaster's own chance of this, stated with the estimate: 20%; at least 2.5-fold (0.39 log units) between middle value and limit.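

For compound 3, only a limit is available in this assay: the limit of > 100000 nM in this assay, at which 1 of the 3 values shown sits.

Exchanging acetyl for (4-methylphenyl)sulfonyl on the oxygen gives an at least 1.9-fold higher number from compound 2 to compound 3 (0.28 log units; that floor lies within the scatter), so the floor alone does not separate compound 3 from compound 2 beyond the scatter. The step to ((4-methylphenyl)sulfonyl)oxy from (5-amino-1,3,4-thiadiazol-2-yl)sulfanyl, an at least 5.2-fold higher number from compound 1 to compound 3 (0.72 log units; beyond the scatter), does clear the scatter, leaving compound 1 with the lowest number of the three at this chain carbon.

Going by these compounds, how far compound 3 truly lies from compound 2 stays open while its value is only a limit. Also open, on these data alone, are whether the lower number of compound 1 follows the sulfanyl link or the thiadiazole group, and how a free hydroxyl or a primary amine on this chain carbon would read.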